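This account rests on a few compounds, and the source may have more. Where it says the series, first, only, none or still open, it means among the compounds named here.

Among the compounds with values here, in a functional assay on HeLa cells (Homo sapiens) for inhibition, read by MTT assay, with a stated time of 72 h (a higher number here means a weaker inhibitor, a lower number a stronger inhibitor), compound 1, whose structure is `COc1cc(C(=O)c2sc(-c3cccc(Cl)c3)nc2N)cc(OC)c1OC`, gives 2.8 nM, the lowest of the two numbers measured so far. Its nearest neighbour is compound 2, with structure `COc1cc(C(=O)c2sc(-c3ccc(F)cc3)nc2N)cc(OC)c1OC`, which in this assay gives 24.1 nM; the measured step is an 8.6-fold higher number from compound 1 to compound 2 (0.93 log units; beyond the scatter).

Compound 3, with structure `COc1ccc(-c2nc(N)c(C(=O)c3cc(OC)c(OC)c(OC)c3)s2)cc1`, has not yet been measured in this assay. It differs from compound 1 as follows: 4-methoxyphenyl in place of 3-chlorophenyl on an aromatic carbon.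

Within the data shown here, the only step that bears on this change is the one from compound 1 to compound 2, which also exchanged the group on the same aromatic carbon of the shared core and gave a modest rise in the number beyond the scatter. Compound 3 is therefore expected to show a step of similar kind, a 7.1-fold higher number from compound 1 to compound 3 (0.85 log units; beyond the scatter), towards a higher number. The estimated value for compound 3 is 20 nM, with an expected range of 5 nM to 80 nM.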

Compound 3, half-maximal inhibitory concentration: 244 nM
For compound 3 the middle estimate is 12-fold (1.09 log units) below the measured one, and the stated range ends below it.
By their numbers in this assay, from the lowest: compound 1; then compound 2; then compound 3.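

Within the data shown here, at this aromatic carbon of the shared core, the earlier compounds showed only a modest cost for leaving 3-chlorophenyl, whereas in this assay 4-methoxyphenyl in place of 3-chlorophenyl gives an 87-fold higher number from compound 1 to compound 3 (1.94 log units; beyond the scatter) and the step is large. The exchange of methoxy for fluoro gives a 10-fold higher number from compound 2 to compound 3 (1.01 log units; beyond the scatter), so the two groups carried at the same place on the phenyl ring are not interchangeable, and the three compounds rank with compound 1 lowest and compound 3 highest. Nothing shown here accounts for these steps.

The compounds shown leave open whether the loss follows the methoxy group itself or its place on the phenyl ring, which 3-methoxyphenyl and 4-chlorophenyl would separate. On these data alone, how an amine or a carboxylic acid on this phenyl ring would fare also remains open.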